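Adding a Methoxy Group to a Weakly Active Flavanonol

A few compounds are considered here, and "the series" means these few. Any claim that something is new, unique, unknown or untested is made for them only; others in the source may bear on it.

Measured so far:
- compound 1 `O=C1c2ccc(O)cc2O[C@@H](c2cccc(O)c2O)[C@@H]1O`: > 100000 nM (a limit)
- compound 2 `COc1ccc2c(c1O)O[C@@H](c1cccc(O)c1O)[C@H](O)C2=O`: 88500 nM
- compound 3 `O=C1c2ccccc2O[C@@H](c2cccc(O)c2O)[C@@H]1O`: > 100000 nM (a limit)

In a functional assay on RAW264.7 cells (Rattus norvegicus) for inhibition, with RAW264.7 (Mus musculus) as the target, read by Griess assay, with stated times of 2 h and 16 h (on this read-out lower numbers stand for stronger inhibition and higher numbers for weaker inhibition), compound 3 reaches only a limit, > 100000 nM. The same holds for compound 1, where the limit is > 100000 nM. Compound 2 gives a measured value, 88500 nM. The step that the two limits leave unreadable from compound 1 to compound 3 cannot be sized, since both ends are limits (the limit of > 100000 nM in this assay, at which 2 of the 3 values shown sit).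

Compound 4 `COc1ccc2c(c1)O[C@@H](c1cccc(O)c1O)[C@H](O)C2=O` differs from compound 3 by methoxy in place of hydrogen on an aromatic carbon. For the measured compounds named here, no measured step tests this exact change, and the nearest values all sit at or near the limit, so the expected step that the limit leaves unreadable from compound 3 to compound 4 is small or not readable. Compound 4 is therefore estimated at 110000 nM, within 40000 nM to 300000 nM, most likely reported as a limit.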

Compound 4, half-maximal inhibitory concentration: 30300 nM
Compound 4: middle estimate off by 3.6-fold (0.56 log units), on the high side; the whole stated range lies above it.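

In this assay, methoxy at this position gives the first clear gain over the bare ring: an at least 3.3-fold lower number from compound 3 to compound 4 (0.51 log units; beyond the scatter). Putting a methyl on the hydroxy at the same position also helps, so the methoxy and the free hydroxy do not behave alike here: an at least 3.3-fold lower number from compound 1 to compound 4 (0.51 log units; beyond the scatter). Removing the other ring hydroxy while keeping the methoxy helps as well, so that hydroxy is not needed for this activity: a 2.9-fold lower number from compound 2 to compound 4 (0.47 log units; beyond the scatter).

As far as these compounds go, whether an ethoxy group or an amine at this position would do better stays open. The true size of the two steps that start from a limit also stays open, because those steps have only one measured end: the limit of > 100000 nM in this assay, at which 2 of the 4 values shown sit.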